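This account rests on a few compounds, and the source may have more. Where it says the series, first, only, none or still open, it means among the compounds named here.

Compound 3 `COc1cc(C(=O)Nc2nn[nH]n2)nc(-c2ccc(Cl)cc2)c1` gives 0% in a functional assay on the whole organism with Rattus norvegicus as the target, at a dose of 1 mg/kg by the oral route (a lower number here means a weaker effect, a higher number a stronger effect of the compound at the dose given), the lowest of the three numbers measured. Compound 1 `O=C(Nc1nn[nH]n1)c1cc(Cl)cc(-c2ccccc2)n1` gives 40% in this assay, and compound 2 `Cc1ccc(-c2cc(Cl)cc(C(=O)Nc3nn[nH]n3)n2)cc1` gives 86% in this assay. Among the compounds with values here, the one measured step, a number 46 percentage points higher from compound 1 to compound 2 (beyond the scatter), came from methyl in place of hydrogen on an aromatic carbon. Compound 4 `CCCc1ccc(-c2cc(OC)cc(C(=O)Nc3nn[nH]n3)n2)cc1` has not yet been measured. Against compound 3 it shows (propyl in place of chloro on an aromatic carbon), on an aromatic carbon of a six-membered aromatic ring of carbon only, para to a large group. Within the data shown here, the step from compound 1 to compound 2 bears on this change, since it too added a carbon chain to a ring of that kind, and it was large; but compound 3 also differs from compounds 1 and 2 elsewhere, and no measured step shows how the core of compound 3 answers such a change. An increase is therefore expected, with wide uncertainty. The expected step is a number 35 percentage points higher from compound 3 to compound 4 (beyond the scatter). Compound 4 is expected to give 35%, between 5% and 70%.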

Compound 4, a percentage reported as inhibition, in the whole organism at one dose (the size of the read-out at that dose, not a potency): 73%
Estimate against measurement, compound 4: 38 percentage points below; measured number above the stated range.
By their numbers in this assay, from the lowest: compound 3; then compound 1; then compound 4; then compound 2.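

In this assay, propyl in place of chloro on an aromatic carbon, para to a large group, gives a number 73 percentage points higher from compound 3 to compound 4 (beyond the scatter) and so shows that the core of compound 3 answers a change at this place. The earlier compounds shown here showed a gain only for methyl in place of hydrogen on the core of compound 1, with a number 46 percentage points higher from compound 1 to compound 2 (beyond the scatter) as the result, whereas here a chloro leaves and a chain of three carbons enters.

The compounds shown do not separate what the loss of chloro contributes from what the arrival of propyl contributes. As far as these compounds go, it also stays open how hydrogen, methyl, a longer chain such as butyl, or an amine would read at this place on the core of compound 3. Nothing measured here gives a reason for the size of this step.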